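This account rests on a few compounds, and the source may have more. Where it says the series, first, only, none or still open, it means among the compounds named here.

Working notes on the series. Within the data shown here, in a functional assay on HeLa cells (Homo sapiens) for cytotoxicity, read by XTT assay, with a stated time of 24 h (a lower number here means a stronger inhibitor, a higher number a weaker inhibitor), compound 1, `Cc1cc(Cl)c2c(c1O)C(=O)C=CC2=O`, gives 10100 nM, the lowest of the three numbers measured so far. Its nearest neighbour is compound 3, `CC(=O)Oc1cc(OC(C)=O)c2c(OC(C)=O)c(C)cc(Cl)c2c1OC(C)=O`, at 27900 nM, and furthest away lies compound 2, `CC(=O)Oc1cc(OC(C)=O)c2c(OC(C)=O)cc(C)c(Cl)c2c1OC(C)=O`, at 52900 nM. Both gaps from compound 1 are beyond the scatter, so compound 1 is the strongest inhibitor of the three in this assay.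

The next compound is compound 4, `CC(=O)Oc1c(C)cc(Cl)c2c1C(=O)C=CC2=O`. It departs from compound 1 in one place, hydroxy to acetoxy, with acetyl in place of hydrogen on an oxygen on an aromatic ring.

Among the measured compounds shown here, no measured pair isolates this change, so the expectation has little direct support. For the measured compounds named here, the only guide is the three measured values, compound 1 at 10100 nM, compound 3 at 27900 nM and compound 2 at 52900 nM, among which compound 1 has the lowest number, and this leans the expectation slightly upward. The estimated step is a 1.4-fold higher number from compound 1 to compound 4 (0.14 log units; within the scatter), a small rise expected to stay within the scatter. For compound 4 the estimated value in this assay is 14000 nM, with an expected range of 5000 nM to 38000 nM.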

Compound 4, half-maximal inhibitory concentration: 21800 nM
Compound 4: middle estimate off by 1.6-fold (0.19 log units), on the low side, within the range that was stated.
By their numbers in this assay, from the lowest: compound 1; then compounds 4, 3 and 2 (each within the scatter of the next, the first and the last beyond it).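

Acetyl in place of hydrogen on this oxygen gives the first direct reading at this position: in this assay, the change is a 2.2-fold higher number from compound 1 to compound 4 (0.33 log units; beyond the scatter), a modest step. The free hydroxy hydrogen is therefore not needed for a measurable effect in this assay, since the acetoxy compound keeps a value in the same broad range, but compound 1 remains the strongest of the four compounds, with every step from it printed as beyond the scatter. Nothing measured for these compounds accounts for the rise.

As far as these compounds go, whether the rise belongs to the acetyl group in particular or would follow any replacement of this hydrogen stays open; a methyl ether, a longer acyl chain such as propanoyl or a carbamate on the same oxygen would separate those readings. The change also rests on this single pair, so its size on the other compounds in the series stays open, as compounds 2 and 3 have no free hydroxy counterparts among those shown.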